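A few compounds are considered here, and "the series" means these few. Any claim that something is new, unique, unknown or untested is made for them only; others in the source may bear on it.

Compound 1, with the structure `CC(C)(C)c1ccc(/C=C/C(=O)Nc2ccc3c(c2)NC(=O)CC3)cc1`, is the stronger of the two measured compounds: in a functional assay on CHO cells for inhibition of transient receptor potential cation channel subfamily V member 1 (Homo sapiens) (a higher number here means a weaker inhibitor, a lower number a stronger inhibitor), compound 1 gives 2.5 nM. Compound 2, with the structure `O=C(/C=C/c1ccccc1)Nc1ccc2c(c1)OCCO2`, shares the cinnamamide link but carries a different core. For compound 2 this assay reports only a limit, > 4000 nM, and not a number; this is the limit at which one of the two values sits (the limit of > 4000 nM in this assay, at which 1 of the 2 values shown sits). Compound 3, with the structure `O=C(/C=C/c1ccc(F)cc1)Nc1ccc2c(c1)OCCO2`, differs from compound 2 in one place: fluoro in place of hydrogen on an aromatic carbon, para to a large group. Among the compounds with values here, no step between measured compounds exists here, so the size of the change in this assay cannot be read from the data; a small change, if any, within the usual scatter is expected. Compound 3 is therefore estimated at 5000 nM, within 1500 nM to 15000 nM, which from compound 2 to compound 3 means the expected step that the limit leaves unreadable from compound 2 to compound 3.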

Compound 3, half-maximal inhibitory concentration: 1000 nM
Beside the measured number, compound 3's estimate is 5.0-fold (0.70 log units) above it, outside the stated range (below it).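

In this assay, the change from phenyl to 4-fluorophenyl gives an at least 4.0-fold lower number from compound 2 to compound 3 (0.60 log units; beyond the scatter), so this position on the aromatic ring does respond to substitution, and a single fluoro is enough to bring compound 3 to a measurable value of 1000 nM. The value of compound 2 is a limit of the assay and not a number: the limit of > 4000 nM in this assay, at which 1 of the 3 values shown sits. The step is therefore a minimum, and its full size cannot be read.

The compounds shown leave open whether chloro, methyl or trifluoromethyl at the same position would give a larger or smaller step than fluoro. They also leave open whether fluoro would have a comparable effect elsewhere on this ring or on the core of compound 1.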